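A Swap at the Carbonyl Carbon of Compound 1

The source may hold more compounds than are shown below. What is called first, only, known or untested is meant among the compounds shown, and "the series" means these compounds.

Going by the values given here, compound 1 `CCc1cc(S(=O)(=O)N2C[C@H](c3ccccc3)NC2=O)ccc1NC(=O)NC1CCCCC1` is the only member of this set with a number in a functional assay on A549 cells (Homo sapiens) for cytotoxicity, read by MTT assay; on this read-out lower numbers stand for stronger inhibition and higher numbers for weaker inhibition: compound 1 gives 500 nM. Compound 2 `CC1[C@H](c2ccccc2)NC(=O)N1S(=O)(=O)c1ccc(NC(=O)c2ccc([N+](=O)[O-])cc2)c(Cl)c1` has only a limit in this assay, and for compound 2 that limit is > 10000 nM. Compound 3 `CC1[C@H](c2ccccc2)NC(=O)N1S(=O)(=O)c1ccc(NC(=O)c2ccc(N)cc2)c(Cl)c1` likewise has only a limit in this assay, and for compound 3 that limit is > 10000 nM. Among the compounds with values here, the single step between measured compounds, a step that the two limits leave unreadable from compound 2 to compound 3, cannot be read because both of its ends sit at the limit of > 10000 nM in this assay, at which 2 of the 3 values shown sit. Compound 4 `CCc1cc(S(=O)(=O)N2C[C@H](c3ccccc3)NC2=O)ccc1NC(=O)OCC(C)C` differs from compound 1 in one place: isobutoxy in place of cyclohexylamino on a carbonyl carbon. Within the data shown here, no measured step touches a change at this carbonyl carbon, so the data give neither size nor direction for it. The expectation is therefore that compound 4 stays near compound 1, with a step of a 1.6-fold higher number from compound 1 to compound 4 (0.20 log units; within the scatter) that may fall within the scatter or a little beyond it toward weaker inhibition. The estimate for compound 4 in this assay is 800 nM, with a range from 250 nM to 3000 nM.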

Compound 4, half-maximal inhibitory concentration: 70 nM
Beside the measured number, compound 4's estimate is 11-fold (1.06 log units) above it; measured number below the stated range.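

In this assay, the carbonyl carbon proves to be a place where the group matters: isobutoxy in place of cyclohexylamino gives a 7.1-fold lower number from compound 1 to compound 4 (0.85 log units; beyond the scatter). Going by these compounds alone, the earlier compounds could not show this, as their only step lies at a different place and cannot be read, with a limit of the assay at both of its ends. The leaving cyclohexylamino carries a six-membered non-aromatic ring and a hydrogen-bond donor, the entering isobutoxy has neither, and nothing shown gives a reason for the step.

This single swap changes the atom on the carbonyl carbon and the carbon part together, so the two effects remain unseparated. A cyclohexyloxy group or an isobutylamino group at this carbon would tell them apart.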